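Removing the methyl from the core of compound 2

A few compounds are considered here, and "the series" means these few. Any claim that something is new, unique, unknown or untested is made for them only; others in the source may bear on it.

Two compounds of this series have numbers in a physicochemical assay for permeability, using PAMPA; a lower number here means that the compound crosses the layer more slowly, a higher number that the compound crosses the layer faster. Compound 1 `Cc1cc(C)cc(NC(=O)COc2ccnc3ccccc23)c1` gives 460 nm/s in this assay. Compound 2 `COc1ccc2nc(C)cc(OCC(=O)Nc3cc(C)cc(C)c3)c2c1` gives 180 nm/s in this assay, the lower of the two numbers, and the gap to compound 1 lies beyond the scatter. Among the measured compounds shown here, the two compounds differ in more than one place, so the two numbers alone show what that gap is; no single step between measured compounds is available.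

Compound 3 `COc1ccc2nccc(OCC(=O)Nc3cc(C)cc(C)c3)c2c1` is not yet measured in this assay. It differs from compound 2 in one place: hydrogen in place of methyl on an aromatic carbon of a six-membered aromatic ring with 1 nitrogen, part of a fused or bridged system of two rings, next to the ring nitrogen. For the measured compounds named here, no step between measured compounds covers such a change, so the expectation rests on compound 2 alone. The step of a 1.1-fold lower number from compound 2 to compound 3 (0.05 log units; within the scatter) is expected to stay within the scatter, with no clear direction. Compound 3 is therefore estimated at 160 nm/s in this assay, within a range from 75 nm/s to 340 nm/s.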

Compound 3, apparent permeability: 280 nm/s
The estimate for compound 3 lay 1.8-fold (0.24 log units) below the measured number; low and high end bracket the measured number.
By their numbers in this assay, from the lowest: compounds 2, 3 and 1 (each within the scatter of the next, the first and the last beyond it).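

In this assay the methyl on the aromatic carbon next to the ring nitrogen can be exchanged without a clear shift: hydrogen in place of methyl gives a 1.6-fold higher number from compound 2 to compound 3 (0.19 log units; within the scatter) and so, at this position in the methoxy-bearing compounds, the change cannot be told apart from repeat scatter. Compound 3 also supplies the second single step of the series, methoxy in place of hydrogen on an aromatic carbon, which gives a 1.6-fold lower number from compound 1 to compound 3 (0.22 log units; within the scatter) and likewise stays within the scatter, so the gap between compound 1 and compound 2, which lies beyond the scatter, now divides into two single steps, neither of which lies beyond the scatter on its own. No measurement at hand accounts for either step.

On these data alone, whether the methyl step would read the same on a core without the methoxy remains open, as the two changes are seen here only with one another in place and how they combine cannot be separated. Also open, as far as these compounds go, is whether a larger or different group on the carbon next to the ring nitrogen, such as an ethyl, a phenyl or an amine, would move the number beyond the scatter.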